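The compounds below may be only part of what the source reports. "The series", "measured", "known", "first", "only" and "open" are said of these compounds alone.

Compound 1, with the structure `CC(C)(CC#Cc1c(Cl)c2c(Cl)cc(C(N)=O)nc2n1[C@H]1CCCNC1)C(N)=O`, was tested in a functional assay on KG-1 cells (Homo sapiens) for antiproliferative activity (a lower number here means that less compound is needed, a higher number that more compound is needed for the effect), where compound 1 gives 269 nM. Compound 2, with the structure `NC(=O)c1cc(Cl)c2c(Cl)c(C#CC3CNCCO3)n([C@H]3CCCNC3)c2n1`, carries two entries in this assay, and compound 2 gives 365 nM; 197 nM (2 entries). Among the compounds with values here, those entries stand in the several entries of compound 2 in this assay, 365 nM; 197 nM (2 entries), and they lie within the usual scatter of each other and of the single value of compound 1, so no order can be read between compound 1 and compound 2 on these numbers. Within the data shown here, compound 1 thus stands with the only single value of its own in this assay, and with nothing yet measured that differs from it in one place.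

Compound 3, with the structure `CC1(CC#Cc2c(Cl)c3c(Cl)cc(C(N)=O)nc3n2[C@H]2CCCNC2)COC1`, differs from compound 1 in one place, (3-methyloxetan-3-yl in place of 1-carbamoyl-1-methylethyl on a saturated chain carbon bound to a triple-bonded carbon). Among the measured compounds shown here, no measured pair in this set carries a change of this kind, so the size of the step is open. The account expects a modest rise in the concentration needed, a step from compound 1 to compound 3 of about a 1.9-fold higher number from compound 1 to compound 3 (0.27 log units; within the scatter), which may still fall within the scatter. In this assay compound 3 is therefore estimated at 500 nM, between 150 nM and 1700 nM.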

Compound 3, half-maximal effective concentration: 289 nM
The estimate for compound 3 lay 1.7-fold (0.24 log units) above the measured number; the range from low to high includes it.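

In this assay, within the data shown here, replacing 1-carbamoyl-1-methylethyl with 3-methyloxetan-3-yl on a saturated chain carbon bound to a triple-bonded carbon gives a 1.1-fold higher number from compound 1 to compound 3 (0.03 log units; within the scatter), the first step that can be read at this place. The group that leaves has a hydrogen-bond donor and a double bond outside aromatic rings, while the group that enters has no donor and brings a four-membered non-aromatic ring, yet compound 1 and compound 3 stay within the scatter of each other. The size of this step is also smaller than the spread between repeat entries of a single compound in this assay: the several entries of compound 2 in this assay, 365 nM; 197 nM (2 entries).

This single step cannot show whether the place tolerates groups in general or only these two, and a carboxylic acid or a primary amine on the same chain could still behave quite differently. Nor does it show how the number would respond to a change elsewhere on the core of compound 1, such as replacing a chlorine or the carboxamide, since compound 2 differs from compound 1 in more than one place and gives no step.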